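Swapping chloro for methoxy on compound 1

The compounds below may be only part of what the source reports. "The series", "measured", "known", "first", "only" and "open" are said of these compounds alone.

- compound 1 `CNC(=O)c1cc(Oc2ccc(NC(=O)c3cc(-c4ccc(Cl)cc4)ncn3)cc2F)ccn1`: > 100000 nM (a limit)
- compound 2 `CNC(=O)c1cc(Oc2ccc(NC(=O)c3cc(-c4ccc(Cl)cc4)ncn3)cc2)ccn1`: > 100000 nM (a limit)
- compound 3 `CNC(=O)c1cc(Oc2ccc(NC(=O)c3cc(-c4ccccc4)ncn3)cc2)ccn1`: 18200 nM

These values come from a functional assay on MCF7 cells (Homo sapiens) for cytotoxicity, read by MTT assay, with a stated time of 72 h; a higher number here means a weaker inhibitor, a lower number a stronger inhibitor. Compound 1 stands at the limit of > 100000 nM in this assay, at which 2 of the 3 values shown sit, and that is a limit and not a number.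

Compound 4 `CNC(=O)c1cc(Oc2ccc(NC(=O)c3cc(-c4ccc(OC)cc4)ncn3)cc2F)ccn1` carries methoxy in place of chloro on an aromatic carbon, para to a large group (methoxy in place of chloro on an aromatic carbon). Among the compounds with values here, no methoxy compound has been measured yet, so the evidence is indirect. The closest guide is an at least 5.4-fold lower number from compound 2 to compound 3 (0.73 log units; beyond the scatter), where hydrogen takes the place of chloro on an aromatic carbon. The other measured change, a step that the two limits leave unreadable from compound 1 to compound 2, cannot be read and offers no guide.

Taking chloro away from compound 2 gave a real number in compound 3, at 18200 nM, so a lower number is expected for compound 4. Compound 4 may still stay at the limit. In this assay the expected step is an at least 2.5-fold lower number from compound 1 to compound 4 (0.39 log units; beyond the scatter). For compound 4 the estimate is 40000 nM, with an expected range of 12000 nM to 100000 nM.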

Compound 4, half-maximal inhibitory concentration: 46200 nM
Estimate against measurement, compound 4: 1.2-fold (0.06 log units) below, and the stated range covers the measured number.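

In this assay, replacing chloro with methoxy gives an at least 2.1-fold lower number from compound 1 to compound 4 (0.33 log units; beyond the scatter), so this position can carry a group other than chloro and still give a readable number. Within the data shown here, until now, the only readable change here was removing chloro altogether, and that was on a compound without the fluoro; this result adds a swap for another group, on the fluoro-bearing compound. The true size of the step stays unknown, as compound 1 has only a limit and not a number: the limit of > 100000 nM in this assay, at which 2 of the 4 values shown sit.

On these data alone, it remains open whether the same swap would give a similar step on compound 2, and the step between compound 1 and compound 2 cannot be read. As far as these compounds go, how an amine, a hydroxyl or a longer chain such as ethoxy would behave in this place also remains open.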